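Hydroxy in place of methoxy on the shared core

A few compounds are considered here, and "the series" means these few. Any claim that something is new, unique, unknown or untested is made for them only; others in the source may bear on it.

Of the compounds shown here, two have been measured in a functional assay on SNB-75 cells (Homo sapiens) for cytotoxicity, read by sulforhodamine B assay, with a stated time of 48 h, tested at 100 nM; a lower number here means a stronger effect, a higher number a weaker effect of the compound at the concentration tested. Compound 1 `Cc1cc(O)cc(-c2nn(CC#N)cc2-c2ccnc(-c3ccc(Oc4ccccc4)cc3)c2)c1` gives 78%, while compound 2 `COc1cc(C)cc(-c2nn(CC#N)cc2-c2ccnc(-c3ccc(N(C)C)cc3)c2)c1` gives -8%. Compound 2 thus stands lowest of the two numbers, and its nearest neighbour, compound 1, sits beyond the scatter above it; the two differ in more than one place, so their values are noted side by side without reading a step from them.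

Compound 3 `Cc1cc(O)cc(-c2nn(CC#N)cc2-c2ccnc(-c3ccc(N(C)C)cc3)c2)c1` is not yet measured. Within the data shown here, it differs from compound 2 by a single change: hydrogen in place of methyl on an oxygen on an aromatic ring Compound 1 carries the same hydroxy group on its 3-hydroxy-5-methylphenyl ring, but no single step involving this change is available.

Given the two numbers in hand, the step from compound 2 to compound 3 in this assay is expected to be a number 33 percentage points higher from compound 2 to compound 3 (beyond the scatter), tending upward but with wide uncertainty. Compound 3 is accordingly estimated at 25%, in a range from -10% to 70%.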

Compound 3, a percentage reported as activity, at one concentration (the size of the read-out at that concentration, not a potency): 77%
The estimate for compound 3 lay 52 percentage points below the measured number; the measured number lies above the stated range.
By their numbers in this assay, from the lowest: compound 2; then compounds 3 and 1 (each within the scatter of the next).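

In this assay, the methyl on the oxygen on the aromatic ring proves decisive: hydrogen in its place gives a number 85 percentage points higher from compound 2 to compound 3 (beyond the scatter) and thus a much weaker effect at the concentration tested. With the hydroxy group present, dimethylamino in place of phenoxy gives a number 1 percentage points lower from compound 1 to compound 3 (within the scatter) and so shows no readable difference, which places the gap between compound 1 and compound 2 on the methoxy to hydroxy change rather than on that exchange. Nothing measured here explains the size of this step.

Going by these compounds, it remains open whether the methoxy group would keep its effect with phenoxy in place of dimethylamino. On these data alone, it is also open how an ethoxy group, a longer chain on the same oxygen, or an amine in place of that oxygen would read in this assay.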